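Moving the furan attachment point in compound 4

The source may report more compounds than this note shows. Statements on the series, on what has been measured and on what is new or still open speak of the compounds shown alone.

Compound 1, `COc1ncnc2c1c(-c1ccccc1)cn2[C@@H]1O[C@H](CO)[C@@H](O)[C@H]1O`: in a functional assay on HCT-116 cells (Homo sapiens), read by MTT assay, with a stated time of 72 h (on this read-out lower numbers stand for stronger inhibition and higher numbers for weaker inhibition), compound 1 gives > 20000 nM, which is a limit of the assay.
Compound 2, `CN(C)c1ncnc2c1c(-c1cc3ccccc3o1)cn2[C@@H]1O[C@H](CO)[C@@H](O)[C@H]1O`: in this assay compound 2 gives > 20000 nM, also a limit of the assay.
Compound 3, `COc1ncnc2c1c(-c1ccco1)cn2[C@@H]1O[C@H](CO)[C@@H](O)[C@H]1O`: in this assay compound 3 gives 40 nM.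

Going by the values given here, compound 3 is the only compound of the three with a number in this assay; the other two sit at the limit of > 20000 nM in this assay, at which 2 of the 3 values shown sit. Among the compounds with values here, the one measured step, an at least 500-fold lower number from compound 1 to compound 3 (2.69 log units; beyond the scatter), is large and shows that the furan-2-yl group brings the potency that phenyl does not.

Compound 4, `COc1ncnc2c1c(-c1ccoc1)cn2[C@@H]1O[C@H](CO)[C@@H](O)[C@H]1O`, is yet to be measured. It differs from compound 3 by furan-3-yl in place of furan-2-yl on an aromatic carbon. Within the data shown here, no measured step covers a shift of the furan attachment point, so the size of the step cannot be read from the data; the large step from compound 1 to compound 3 shows only that this position is sensitive. Compound 4 is therefore expected to stay below the limit but to lose some potency, with an estimated 10-fold higher number from compound 3 to compound 4 (1.00 log units; beyond the scatter). Compound 4 is estimated at 400 nM in this assay, within a range of 40 nM to 6000 nM.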

Compound 4, half-maximal inhibitory concentration: 110 nM
Compound 4: middle estimate off by 3.6-fold (0.56 log units), on the high side, and the stated range covers the measured number.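

Moving the attachment point of the furan changes the number in this assay only modestly, with a 2.8-fold higher number from compound 3 to compound 4 (0.44 log units; beyond the scatter), so the position tells furan-2-yl from furan-3-yl but tolerates both. The phenyl comparison gives an at least 180-fold lower number from compound 1 to compound 4 (2.25 log units; beyond the scatter), so the gain seen with compound 3 does not depend on a single attachment point of the furan. This comparison rests on a limit for phenyl and not on a number: the limit of > 20000 nM in this assay, at which 2 of the 4 values shown sit.

The compounds shown leave open how other five-membered aromatic rings, such as thiophene or pyrrole, would behave at this position. They also leave open whether furan-2-yl or furan-3-yl would keep this potency if an amine replaced the methoxy group on the shared core, and compound 2 cannot settle this, as it differs from compound 3 in more than one place.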